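The source may report more compounds than this note shows. Statements on the series, on what has been measured and on what is new or still open speak of the compounds shown alone.

Three compounds share one core, differing only in the group on the aryl ring. Compound 1 `Cn1c(-c2ccc(-c3cncnc3)cc2)nnc1C1(c2ccc(Cl)cc2)CCC1` was tested in an assay on isolated protein for inhibition of 11-beta-hydroxysteroid dehydrogenase type 2 (Mus musculus); a lower number here means a stronger inhibitor, a higher number a weaker inhibitor; for compound 1 the value > 4000 nM is a limit of the assay, not a number. Compound 2 `Cn1c(-c2ccc(C(=O)NC3CC3)cc2)nnc1C1(c2ccc(Cl)cc2)CCC1` gives > 4000 nM, likewise a limit. Compound 3 `Cn1c(-c2ccc(C(=O)O)cc2Cl)nnc1C1(c2ccc(Cl)cc2)CCC1` gives > 4000 nM, again a limit. The step that the two limits leave unreadable from compound 1 to compound 2 cannot be read, since both ends rest at the limit of > 4000 nM in this assay, at which 3 of the 3 values shown sit. Compound 4 `CCNC(=O)c1ccc(-c2nnc(C3(c4ccc(Cl)cc4)CCC3)n2C)cc1` differs from compound 2 by ethyl in place of cyclopropyl on an amide-type nitrogen. Among the compounds with values here, no readable step bears on this change, and every value so far sits at the limit, so compound 4 is expected to stay there as well. For compound 4 the estimate is 8000 nM, in a range from 3000 nM to 30000 nM. The expected step is a step that the limit leaves unreadable from compound 2 to compound 4, nothing beyond the scatter.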

Compound 4, half-maximal inhibitory concentration: > 4000 nM
Compound 4: no number, only a limit; the forecaster's own chance of this, stated with the estimate: 85%; the middle value does not contradict the limit.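

Within the data shown here, no step from compound 1 or compound 2 to compound 4 can be read, since compound 4 also gives only a limit, not a number: the limit of > 4000 nM in this assay, at which 4 of the 4 values shown sit.

The compounds shown leave open how strongly each one acts in this assay, and whether ethyl in place of cyclopropyl changes that.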